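Naphthalen-1-yl replaces the aryloxy group on the quinoline-like core

The compounds below may be only part of what the source reports. "The series", "measured", "known", "first", "only" and "open" are said of these compounds alone.

Three compounds share a core and differ only in the group attached to one aromatic carbon. Compound 1 `COc1ccc(F)cc1CNCCCNc1ccnc2cc(Cc3ccccc3)ccc12` gives 23 10^-6 cm/s in an ADME assay for permeability, using PAMPA, with a stated time of 30 min, at pH 7.4 (on this read-out higher numbers stand for higher permeability and lower numbers for lower permeability), and compound 2 `COc1ccc(F)cc1CNCCCNc1ccnc2cc(Cc3cccc(C(F)(F)F)c3)ccc12` gives 23 10^-6 cm/s; the step of no change at the digits printed from compound 1 to compound 2 (within the scatter) lies within the scatter. Compound 3 `COc1ccc(F)cc1CNCCCNc1ccnc2cc(Oc3ccc(C(C)(C)C)cc3)ccc12` gives 317 10^-6 cm/s and stands highest of the three numbers, because a 14-fold higher number from compound 1 to compound 3 (1.14 log units; beyond the scatter) and a 14-fold higher number from compound 2 to compound 3 (1.14 log units; beyond the scatter) are both large and beyond the scatter.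

Compound 4 `COc1ccc(F)cc1CNCCCNc1ccnc2cc(-c3cccc4ccccc34)ccc12` is not yet measured. It differs from compound 3 in one place: naphthalen-1-yl in place of 4-(tert-butyl)phenoxy on an aromatic carbon. Within the data shown here, no measured step covers exactly this change. The two steps that bear on it are a 14-fold higher number from compound 1 to compound 3 (1.14 log units; beyond the scatter) and a 14-fold higher number from compound 2 to compound 3 (1.14 log units; beyond the scatter), in which a 4-(tert-butyl)phenoxy group in place of a benzyl or 3-(trifluoromethyl)benzyl group raised the number strongly. Compound 4 carries a naphthalen-1-yl group attached directly to the aromatic carbon, without the oxygen and without the tert-butyl, and so sits structurally between the benzyl compounds and compound 3. The author therefore expects a lower number for compound 4 than for compound 3, estimated as a 4.0-fold lower number from compound 3 to compound 4 (0.60 log units; beyond the scatter), though smaller than the measured rise. The estimated value for compound 4 is 80 10^-6 cm/s, with a range from 25 10^-6 cm/s to 250 10^-6 cm/s.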

Compound 4, apparent permeability: 237 10^-6 cm/s
Beside the measured number, compound 4's estimate is 3.0-fold (0.47 log units) below it; measured number inside the range.
By their numbers in this assay, from the lowest: compounds 1 and 2 (each within the scatter of the next); then compounds 4 and 3 (each within the scatter of the next).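

In this assay, the step of a 1.3-fold lower number from compound 3 to compound 4 (0.13 log units; within the scatter) shows that 4-(tert-butyl)phenoxy can give way to naphthalen-1-yl on this aromatic carbon with no change that can be told from the scatter, so the high number of compound 3 does not depend on that one group, with its oxygen and its tert-butyl. Naphthalen-1-yl also stands well clear of the benzyl-type groups, with a 10-fold higher number from compound 1 to compound 4 (1.01 log units; beyond the scatter) and a 10-fold higher number from compound 2 to compound 4 (1.01 log units; beyond the scatter), so compound 3 is no longer the only compound separated from the first two. Two groups with different counts, one with a single six-membered aromatic ring of carbon only and a hydrogen-bond acceptor, the other with two such rings and no acceptor, thus share that separation, and nothing available explains why they do.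

The compounds shown leave open how a plain phenoxy, a phenyl or a naphthalen-2-yl group would read on this carbon, and so which part of the two larger groups goes with the higher numbers. They also leave open whether an amine or a carboxylic acid at the same place would keep numbers of this size.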